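Dimethyl hydroxyphenyl hydrazone following the bromo analogue

The source may hold more compounds than are shown below. What is called first, only, known or untested is meant among the compounds shown, and "the series" means these compounds.

Compound 3 `CN(C)CCn1cnnc1-c1cc(Oc2ccc(NC(=O)N/N=C/c3ccc(O)c(Br)c3)cc2F)ccn1` gives 12400 nM in a functional assay on U-87MG ATCC cells (Homo sapiens) for cytotoxicity, read by MTT assay, with a stated time of 72 h; a lower number here means a stronger inhibitor, a higher number a weaker inhibitor. Of the two numbers shown compound 3 gives the higher value, though a 1.6-fold higher number from compound 2 to compound 3 (0.20 log units; within the scatter) lies within the scatter, with compound 2 `CN(C)CCn1cnnc1-c1cc(Oc2ccc(NC(=O)N/N=C/c3ccc(O)cc3)cc2F)ccn1` giving 7750 nM. Compound 1 `CN(C)CCn1cnnc1-c1cc(Oc2ccc(NC(=O)N/N=C/c3cccc(O)c3)cc2F)ccn1` gives only a limit of the assay, > 100000 nM. The steps of an at least 12-fold lower number from compound 1 to compound 2 (1.11 log units; beyond the scatter) and an at least 8.0-fold lower number from compound 1 to compound 3 (0.90 log units; beyond the scatter) set the 4-hydroxyphenyl arrangement well apart from the 3-hydroxyphenyl one. Compound 4 `Cc1cc(/C=N/NC(=O)Nc2ccc(Oc3ccnc(-c4nncn4CCN(C)C)c3)c(F)c2)cc(C)c1O` has not been measured; it differs from compound 3 by 4-hydroxy-3,5-dimethylphenyl in place of 3-bromo-4-hydroxyphenyl on a carbon with a double bond to nitrogen. Within the data shown here, the nearest precedent is the bromo-for-hydrogen change, which stayed within the scatter, so no step beyond the scatter is expected, a 1.4-fold lower number from compound 3 to compound 4 (0.14 log units; within the scatter). Compound 4 is therefore estimated at 9000 nM, expected to fall between 3000 nM and 30000 nM.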

Compound 4, half-maximal inhibitory concentration: 7710 nM
Estimate against measurement, compound 4: 1.2-fold (0.07 log units) above; measured number inside the range.
By their numbers in this assay, from the lowest: compounds 4, 2 and 3 (each within the scatter of the next). At a limit, above all of these: compound 1.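

In this assay, the 4-hydroxyphenyl tolerates two added methyl groups (a 1.0-fold lower number from compound 2 to compound 4 (0.00 log units; within the scatter)), and 4-hydroxy-3,5-dimethylphenyl matches the bromo group of 3-bromo-4-hydroxyphenyl within the scatter (a 1.6-fold lower number from compound 3 to compound 4 (0.21 log units; within the scatter)). The gap to the 3-hydroxyphenyl arrangement therefore now holds for a third compound carrying the 4-hydroxy group (an at least 12-fold lower number from compound 1 to compound 4 (1.11 log units; beyond the scatter)). Compound 1 gives only a limit, not a number: (the limit of > 100000 nM in this assay, at which 1 of the 4 values shown sits). From the compounds shown here alone, whether a methoxy group, an amine or a carboxylic acid in place of that hydroxyl would keep these numbers remains open.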